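Hydroxy for methoxy on the side chain of compound 2

A few compounds are considered here, and "the series" means these few. Any claim that something is new, unique, unknown or untested is made for them only; others in the source may bear on it.

Measured so far in an assay for binding affinity to Corticotropin releasing factor receptor (Rattus norvegicus); a lower number here means a stronger inhibitor, a higher number a weaker inhibitor:
compound 1 `CCCC(C)n1c(CC)nc2c(-c3ccc(OC)cc3C)ccnc21` gives 0.8 nM
compound 2 `CCCC(C)n1c(CC)nc2c(-c3ccc(C(C)OC)cc3Cl)ccnc21` gives 3.5 nM
compound 3 `CCC(CCOC)n1c(OC)nc2c(-c3ccc(OC(F)(F)F)cc3Cl)ccnc21` gives 1.9 nM

Compound 2 has the highest of the three numbers in this assay. Its gap to compound 3 is within the usual scatter, so the two cannot be ordered; its gap to compound 1, whose number is lower, lies beyond the scatter. The three compounds differ at several places at once, so no single change among them can be read off.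

Compound 4 `CCCC(C)n1c(CC)nc2c(-c3ccc(C(C)O)cc3Cl)ccnc21` has not yet been measured. It differs from compound 2 in one place: hydrogen in place of methyl on an oxygen on a saturated carbon. The rest of the molecule, including the shared core, the substituted side chain on the core and the second aromatic ring, is kept unchanged.

Going by the values given here, no step of this kind is available among the measured compounds, so the expectation rests on the structural change alone. For compound 4 in this assay the step of a 1.4-fold higher number from compound 2 to compound 4 (0.15 log units; within the scatter) is expected to be small, with a slightly higher number, and to stay within the scatter. Compound 4 is estimated at 5 nM, with a range from 1.5 nM to 15 nM.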

Compound 4, inhibition constant: 5.1 nM
Compound 4: the middle estimate sits 1.0-fold (0.01 log units) below what was measured; the range from low to high includes it.
By their numbers in this assay, from the lowest: compound 1; then compounds 3, 2 and 4 (each within the scatter of the next, the first and the last beyond it).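

In this assay, going by these compounds alone, going from 1-methoxyethyl to 1-hydroxyethyl gives a 1.5-fold higher number from compound 2 to compound 4 (0.16 log units; within the scatter), the first step that can be read at a single place, since the earlier compounds differ at several places at once. At this position, hydrogen in place of methyl on the oxygen therefore leaves the number within the scatter, so the methyl on the oxygen shows no measurable contribution in this comparison. Nothing at hand bears on why the two compounds read alike.

The compounds shown leave open how an amine or a carboxylic acid at this place, or a longer chain on the oxygen such as ethoxy, would read in this assay. They also leave open whether hydroxy for methoxy gives a step of similar size on a compound with a different side chain on the shared core.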